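This account rests on a few compounds, and the source may have more. Where it says the series, first, only, none or still open, it means among the compounds named here.

In an ADME assay on HaCaT cells (Homo sapiens) for antiproliferative activity, with a stated time of 48 h (on this read-out higher numbers stand for weaker inhibition and lower numbers for stronger inhibition), compound 1 `CCOC(=O)c1ccc(-c2ccc(N(CC)CC)nn2)cc1` gives 500 nM. Compound 2 `CCOC(=O)c1ccc(-c2ccc(OCC)nn2)cc1` reads > 25000 nM, which is a limit of the assay and not a number. Only that limit is available for placing compound 2: the limit of > 25000 nM in this assay, at which 1 of the 2 values shown sits.

Compound 3 `CCOC(=O)c1ccc(-c2ccc(OC(C)C)nn2)cc1` differs from compound 2 by methyl in place of hydrogen on a saturated chain carbon bound to an oxygen on an aromatic ring and a saturated chain carbon, that is, ethoxy to isopropoxy. Going by the values given here, one measured step bears on this, and only indirectly: an at least 50-fold higher number from compound 1 to compound 2 (1.69 log units; beyond the scatter). Among the compounds with values here, that step is large, but it replaces diethylamino with ethoxy, and no measured step covers ethyl to isopropyl. Compound 3 also lacks the diethylamino group, so no return towards the value of compound 1 is expected. In this assay no change beyond the scatter is expected, in either direction. The expected step is a number no higher from compound 2 to compound 3 (the limit leaves the size open). For compound 3 the estimate is 25000 nM, with an expected range of 10000 nM to 50000 nM.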

Compound 3, half-maximal inhibitory concentration: > 25000 nM
Compound 3 ended at the assay's limit; the forecaster's own chance of this, stated with the estimate: 80%; the middle value sits exactly at the limit.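

Ethoxy to isopropoxy gives no readable comparison: in this assay compound 2 and compound 3 both stand at a limit of the assay and not at a number, so the step between them cannot be read. Isopropoxy in place of diethylamino gives an at least 50-fold higher number from compound 1 to compound 3 (1.69 log units; beyond the scatter), so the large step seen with ethoxy also appears with a second oxygen-linked group. Methyl in place of hydrogen on a saturated chain carbon bound to an oxygen on an aromatic ring and a saturated chain carbon does not bring the read-out off the limit: the limit of > 25000 nM in this assay, at which 2 of the 3 values shown sit.

Open, as far as these compounds go, is whether another amine, such as dimethylamino or a cyclic amine like piperidine, keeps a value near that of compound 1. Also open, from the compounds shown here alone, is whether a longer chain on the oxygen gives any readable value.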